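Fluoro in place of methylsulfanyl on the anilide ring

A few compounds are considered here, and "the series" means these few. Any claim that something is new, unique, unknown or untested is made for them only; others in the source may bear on it.

Measured compounds:
compound 1 `CSc1cccc(NC(=O)CN2CCC(c3cccc[n+]3[O-])CC2)c1`: 100 nM
compound 2 `Cc1ccc(Cl)c(NC(=O)CN2CCC(c3cccc[n+]3[O-])CC2)c1Cl`: 346 nM
compound 3 `Cc1cccc(NC(=O)CN2CCC(c3ccccc3F)CC2)c1`: 1 nM

In a functional assay on HEK293 cells for agonist activity at D(4) dopamine receptor (Homo sapiens), read by FLIPR (a higher number here means that more compound is needed for the effect, a lower number that less compound is needed), compound 1 gives 100 nM, the second highest of the three numbers. Its nearest neighbour is compound 2, which gives 346 nM, a higher number that lies beyond the scatter. Furthest away is compound 3, which gives 1 nM, a far lower number, also beyond the scatter; compound 3 differs from compound 1 in more than one place, so the two values show only that the compounds differ widely.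

Compound 4 `O=C(CN1CCC(c2cccc[n+]2[O-])CC1)Nc1cccc(F)c1` has not yet been measured in this assay. Set against compound 1, it carries a single change: fluoro in place of methylsulfanyl on an aromatic carbon. The change sits on an aromatic carbon of a six-membered aromatic ring of carbon only, meta to a large group, and the rest of the shared core is untouched.

Within the data shown here, no measured pair shows this particular change, so its size cannot be read from the data. Compound 4 is expected to stay close to compound 1, with the step of a 1.5-fold higher number from compound 1 to compound 4 (0.18 log units; within the scatter) expected to be small, at most a modest move toward a higher number, and quite possibly within the scatter. Compound 4 is therefore estimated at 150 nM in this assay, with a range from 40 nM to 600 nM.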

Compound 4, half-maximal effective concentration: 160 nM
Compound 4: the middle estimate sits 1.1-fold (0.03 log units) below what was measured, within the range that was stated.
By their numbers in this assay, from the lowest: compound 3; then compounds 1 and 4 (each within the scatter of the next); then compound 2.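

In this assay, among these compounds, the exchange of methylsulfanyl for fluoro gives the first step that can be read for a single change, a 1.6-fold higher number from compound 1 to compound 4 (0.20 log units; within the scatter), and this step lies within the scatter. At this place, on an aromatic carbon meta to a large group and with the shared core untouched, going from a group of two heavy atoms with one hydrogen-bond acceptor to a group of one heavy atom with none therefore leaves no change in the number that can be told apart from the scatter of repeated measurements. No independent measurement bears on why the two compounds read alike, so the result stands as an observation without an explanation.

This single pair cannot show whether the position tolerates change in general, since an amine, a carboxylic acid or a longer chain such as ethylsulfanyl on the same aromatic carbon could behave quite differently. Going by these compounds, it also remains open whether fluoro in place of methylsulfanyl would give an equally small step on a different core, or at another position on this ring.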